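Replacing a Piperidinylsulfonyl Group with a Pyridinylcarbonyl Group

The source may hold more compounds than are shown below. What is called first, only, known or untested is meant among the compounds shown, and "the series" means these compounds.

Of the compounds shown here, two sharing one core have been measured in an ADME assay on cells (Hepatocyte, Rattus norvegicus) for metabolic stability; a higher number here means faster removal of the compound, a lower number slower removal. Compound 1 `Cc1ccc2[nH]c(C(=O)N[C@H]3CCN(S(=O)(=O)c4ccccc4)C[C@@H]3C(=O)NCCN(C)C)cc2c1` gives 16 uL/min in this assay, and compound 2 `Cc1ccc2[nH]c(C(=O)N[C@H]3CCN(S(=O)(=O)N4CCCCC4)C[C@@H]3C(=O)NCCN(C)C)cc2c1` gives 25 uL/min. Among the compounds with values here, the one measured step, a 1.6-fold higher number from compound 1 to compound 2 (0.19 log units; within the scatter), changes only the substituent on the sulfonyl sulfur. Compound 2 has the highest of the two numbers, but its step from compound 1 is within the scatter, so the two compounds cannot be told apart on this assay.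

Compound 3 `Cc1ccc2[nH]c(C(=O)N[C@H]3CCN(C(=O)c4cccnc4)C[C@@H]3C(=O)NCCN(C)C)cc2c1` is not yet measured. It differs from compound 2 by (pyridin-3-yl)carbonyl in place of (piperidin-1-yl)sulfonyl on an amine nitrogen in a ring. Within the data shown here, no measured step bears directly on this change: the only step available keeps the sulfonyl group and swaps what is attached to it, whereas here the whole (piperidin-1-yl)sulfonyl group leaves and a (pyridin-3-yl)carbonyl group enters on the amine nitrogen in the ring. Among the measured compounds shown here, with only that step as a guide, and it being within the scatter, no shift beyond the scatter is expected in this assay. Compound 3 is therefore estimated at 22 uL/min, with a range from 10 uL/min to 48 uL/min. The step this estimate implies, a 1.1-fold lower number from compound 2 to compound 3 (0.06 log units; within the scatter), is expected to stay within the scatter.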

Compound 3, intrinsic clearance in a liver preparation (reported as CLH), per the amount of preparation that the assay uses: 6 uL/min
Compound 3: middle estimate off by 3.7-fold (0.56 log units), on the high side, and the stated range ends above it.
By their numbers in this assay, from the lowest: compound 3; then compounds 1 and 2 (each within the scatter of the next).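

On the amine nitrogen in the ring, the result shows that exchanging the whole group matters more in this assay than changing only what sits on the sulfonyl sulfur: the sulfur change gave a 1.6-fold higher number from compound 1 to compound 2 (0.19 log units; within the scatter) and the exchange for (pyridin-3-yl)carbonyl gave a 4.2-fold lower number from compound 2 to compound 3 (0.62 log units; beyond the scatter) with the number moving clearly down. The outcome does not depend on which of the two sulfonyl compounds is the starting point, since the same exchange made from the phenylsulfonyl group gave a 2.7-fold lower number from compound 1 to compound 3 (0.43 log units; beyond the scatter) and so leaves compound 3 lowest of the three, with slower removal than either sulfonyl compound. Nothing available here explains why the number falls with this exchange.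

These compounds do not separate the part played by the carbonyl linker from that of the pyridine ring, since both arrive together in compound 3. A benzoyl group or a (piperidin-1-yl)carbonyl group on the same amine nitrogen would pull the two apart, and a pyridin-4-yl ring in place of the pyridin-3-yl ring would test whether the placing of the ring nitrogen counts.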